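Swapping ethoxy for chloro on an aromatic ring

The source may report more compounds than this note shows. Statements on the series, on what has been measured and on what is new or still open speak of the compounds shown alone.

In a functional assay on A2780 cells (Homo sapiens) for antiproliferative activity, read by MTT assay, with a stated time of 48 h (on this read-out higher numbers stand for weaker inhibition of growth and lower numbers for stronger inhibition of growth), compound 1 `COC(=O)N1N=C(c2cccc(OC)c2)CC1c1cc(OC)c(OC)c(OC)c1` gives 2780 nM, and compound 2 `CCOc1cccc(C2=NN(C(=O)OC)C(c3cc(OC)c(OC)c(OC)c3)C2)c1` gives 760 nM. Compound 2 therefore holds the lower of the two numbers, which means the stronger inhibition of growth so far. The next structure, compound 3 `COC(=O)N1N=C(c2cccc(Cl)c2)CC1c1cc(OC)c(OC)c(OC)c1`, has chloro in place of ethoxy on an aromatic carbon, meta to a large group: chloro in place of ethoxy on an aromatic carbon. Among the compounds with values here, only one measured step bears on this change: a 3.7-fold lower number from compound 1 to compound 2 (0.56 log units; beyond the scatter). That modest step came from adding a methyl to the group that now leaves. It does not show how chloro behaves, so it offers only a weak guide. Losing the ethoxy may give back a similar amount, so the expected result in this assay is a 2.0-fold higher number from compound 2 to compound 3 (0.30 log units; within the scatter), towards weaker inhibition. For compound 3 the estimated value is 1500 nM, within a range of 450 nM to 5000 nM.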

Compound 3, concentration for 50% growth inhibition: 1540 nM
Compound 3: the middle estimate sits 1.0-fold (0.01 log units) below what was measured, within the range that was stated.
By their numbers in this assay, from the lowest: compound 2; then compounds 3 and 1 (each within the scatter of the next).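

This position tolerates more than one kind of group, but the choice still matters: in this assay there is a 2.0-fold higher number from compound 2 to compound 3 (0.31 log units; beyond the scatter), so compound 2 stays the most potent of the three. Chloro and methoxy, however, cannot be told apart, since a 1.8-fold lower number from compound 1 to compound 3 (0.26 log units; within the scatter), which shows that a group with no oxygen can hold about the same level here as methoxy. No measurement is available to explain either step.

From the compounds shown here alone, whether the rise from methoxy to ethoxy would continue with a longer chain such as propoxy remains open. So does the effect of a different kind of group on this aromatic carbon, such as an amine, a carboxylic acid or another halogen like fluoro.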